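The source may report more compounds than this note shows. Statements on the series, on what has been measured and on what is new or still open speak of the compounds shown alone.

In a functional assay on MCF7 cells (Homo sapiens) for inhibition, read by MTT assay, with a stated time of 72 h (a higher number here means a weaker inhibitor, a lower number a stronger inhibitor), compound 1 `O=[N+]([O-])c1ccc(-c2nnc(SCCCN3CCN(c4nc5ccccc5o4)CC3)o2)cc1`, which carries nitro on an aromatic carbon, gives 90100 nM. Compound 2 `Brc1ccc(-c2nnc(SCCCN3CCN(c4nc5ccccc5o4)CC3)o2)cc1`, with bromo in that place, gives 115000 nM. Compound 3 `CC(C)(C)Oc1ccc(-c2nnc(SCCCN3CCN(c4nc5ccccc5o4)CC3)o2)cc1`, with tert-butoxy there, gives 94900 nM. Compound 3 therefore stands level with the other two, since its value lies within the usual scatter of both.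

The next compound, compound 4 `c1ccc(-c2nnc(SCCCN3CCN(c4nc5ccccc5o4)CC3)o2)cc1`, has no such group at all: hydrogen in place of tert-butoxy on an aromatic carbon. This is hydrogen in place of tert-butoxy on an aromatic carbon, para to a large group, so 4-(tert-butoxy)phenyl becomes phenyl.

Going by the values given here, three measured steps bear on this change, all of them swaps at that same place: a 1.3-fold higher number from compound 1 to compound 2 (0.11 log units; within the scatter), a 1.1-fold higher number from compound 1 to compound 3 (0.02 log units; within the scatter) and a 1.2-fold lower number from compound 2 to compound 3 (0.08 log units; within the scatter). Each one stays within the scatter, so nitro, bromo and tert-butoxy cannot be told apart by their numbers. None of these steps involves hydrogen, however, so the new compound remains a real test. No step beyond the scatter is expected in this assay, in either direction. The estimated step is small: a 1.1-fold higher number from compound 3 to compound 4 (0.02 log units; within the scatter). For compound 4 the estimated value is 100000 nM, with an expected range from 55000 nM to 175000 nM.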

Compound 4, half-maximal inhibitory concentration: 117000 nM
Beside the measured number, compound 4's estimate is 1.2-fold (0.07 log units) below it; the range from low to high includes it.
By their numbers in this assay, from the lowest: compounds 1, 3, 2 and 4 (each within the scatter of the next).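

In this assay hydrogen in place of tert-butoxy (a 1.2-fold higher number from compound 3 to compound 4 (0.09 log units; within the scatter)), in place of bromo (a 1.0-fold higher number from compound 2 to compound 4 (0.01 log units; within the scatter)) and in place of nitro (a 1.3-fold higher number from compound 1 to compound 4 (0.11 log units; within the scatter)) all stay within the scatter. The earlier compounds shown here only compared one group with another, whereas compound 4 has no group on this aromatic carbon at all and still cannot be told apart from compound 1, compound 2 or compound 3. Among these four compounds, then, what sits at this place makes no readable difference to the number, from a lone hydrogen up to the 5 heavy atoms of tert-butoxy, and no measurement at hand says why the values stay level.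

Still open, as far as these compounds go, is whether a group of another kind on this same aromatic carbon, such as an amine or a carboxylic acid, would move the number beyond the scatter. From the compounds shown here alone, all four compounds also share everything else in their structure, so it remains unknown whether a change elsewhere, such as a shorter or longer chain in the shared core, would matter more than this position does.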